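The compounds below may be only part of what the source reports. "The series", "measured", "known", "first", "only" and "open" are said of these compounds alone.

Measured so far:
compound 1 `CCCCc1nc(=O)c(S(=O)(=O)c2ccc(-c3ccc(F)nc3)cc2)c(O)n1-c1c(OC)cccc1OC` — 69%
compound 2 `CCCCc1nc(=O)c(S(=O)(=O)c2ccc(-n3ccccc3=O)cc2)c(O)n1-c1c(OC)cccc1OC` — 63%

Both numbers come from an ADME assay on microsomes from liver (Mus musculus) for metabolic stability, using NADPH, with a stated time of 10 min; on this read-out higher numbers stand for a more stable compound and lower numbers for a less stable compound. In this assay, among the compounds with values here, compound 1 gives 69%, and the only other compound, compound 2, gives 63%. The two cannot be separated on this read-out, because a number 6 percentage points lower from compound 1 to compound 2 (within the scatter) lies within the scatter, so neither stands apart from the other.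

The step considered here leads from compound 1 to compound 3 `COc1cccc(OC)c1-n1c(COC(C)C)nc(=O)c(S(=O)(=O)c2ccc(-c3ccc(F)nc3)cc2)c1O`. The difference is isopropoxy in place of propyl on a saturated chain carbon bound to an aromatic carbon; cut one bond further out it reads butyl to isopropoxymethyl. Within the data shown here, no measured step bears on this change: the single step from compound 1 to compound 2 alters a group at another place of the shared core, and it was itself within the scatter. Nothing among the two measured compounds shows how this assay answers to an exchange of propyl for isopropoxy on the chain.

The expectation therefore rests on compound 1 alone, with a wide range. A step of a number 9 percentage points lower from compound 1 to compound 3 (within the scatter) is expected, which would stay within the scatter. Compound 3 is estimated at 60%, with a range from 38% to 80%.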

Compound 3, percent of the compound remaining: 90%
For compound 3 the middle estimate is 30 percentage points below the measured one; measured number above the stated range.
By their numbers in this assay, from the lowest: compounds 2 and 1 (each within the scatter of the next); then compound 3.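

In this assay, the saturated chain carbon bound to an aromatic carbon proves to be a place where a single exchange can move the read-out: putting isopropoxy in place of propyl gives a number 21 percentage points higher from compound 1 to compound 3 (beyond the scatter), whereas the earlier exchange at another place of the shared core gave a number 6 percentage points lower from compound 1 to compound 2 (within the scatter). Compound 3 therefore stands apart from compound 1 on this read-out, which the first two compounds, lying within the scatter of each other, could not show for any change. The change itself adds an oxygen and one more heavy atom to the chain, but the data offered here include no separate measurement that explains the higher number.

With only this one exchange at this place, the compounds shown cannot separate the part played by the oxygen from that of the branched end, which a straight propoxy group or an all-carbon isobutyl group at the same place would help to tell apart. From the compounds shown here alone, it also stays open whether the same exchange would give a similar step on compound 2, which carries a different group elsewhere on the shared core.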